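This account rests on a few compounds, and the source may have more. Where it says the series, first, only, none or still open, it means among the compounds named here.

Working notes on the series, followed in an in vivo ADME assay on the whole organism for metabolic stability, with Rattus norvegicus as the target; a higher number here means that the compound lasts longer, a lower number that the compound disappears faster. Among the measured compounds shown here, compound 2 (`CC(C)c1onc(-c2c(Cl)cncc2Cl)c1COc1ccc(/C=C/c2cccc(C(=O)O)c2)c(Cl)c1`) gives 0.867 h, the lower of the two numbers so far, and compound 1 (`CC(C)c1onc(COc2c(Cl)cc(F)cc2Cl)c1COc1ccc(/C=C/c2cccc(C(=O)O)c2)c(Cl)c1`) gives 2.33 h. The next structure is compound 3 (`CC(C)c1onc(COc2c(Cl)cccc2Cl)c1COc1ccc(/C=C/c2cccc(C(=O)O)c2)c(Cl)c1`). The change from compound 2 is (2,6-dichlorophenoxy)methyl in place of 3,5-dichloropyridin-4-yl on an aromatic carbon, with the new group on an aromatic carbon of the five-membered aromatic ring, next to the ring nitrogen.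

For the measured compounds named here, only one measured step bears on this: a 2.7-fold lower number from compound 1 to compound 2 (0.43 log units; beyond the scatter), modest but beyond the scatter. It replaced (2,6-dichloro-4-fluorophenoxy)methyl with 3,5-dichloropyridin-4-yl, so the present change runs largely the opposite way. Going by the values given here, compound 3 differs from compound 1 only in carrying (2,6-dichlorophenoxy)methyl in place of (2,6-dichloro-4-fluorophenoxy)methyl, and no measured pair isolates that difference. The expectation therefore rests on compound 1 at 2.33 h, with added uncertainty for this untested difference. A rise of similar size is expected, estimated as a 2.3-fold higher number from compound 2 to compound 3 (0.36 log units; beyond the scatter). The estimate for compound 3 is 2 h, with an expected range from 1 h to 3.8 h.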

Compound 3, half-life: 2.17 h
Compound 3: the middle estimate sits 1.1-fold (0.04 log units) below what was measured; measured number inside the range.
By their numbers in this assay, from the lowest: compound 2; then compounds 3 and 1 (each within the scatter of the next).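

In this assay the exchange of 3,5-dichloropyridin-4-yl for (2,6-dichlorophenoxy)methyl, on the aromatic carbon next to the ring nitrogen, gives a 2.5-fold higher number from compound 2 to compound 3 (0.40 log units; beyond the scatter) and so shows that the gap seen with compound 1 is not tied to that one fluorinated group. Among the compounds shown here, with hydrogen in place of fluoro on an aromatic carbon the record shows a 1.1-fold lower number from compound 1 to compound 3 (0.03 log units; within the scatter), so the fluoro makes no readable difference here, and compound 1 and compound 3 both stand apart from compound 2, the one compound with 3,5-dichloropyridin-4-yl at this place. Nothing at hand explains these numbers.

The change from compound 2 to compound 3 alters the ring nitrogen and the link through oxygen and a methylene at the same time, so the compounds shown cannot assign the gap to either feature. Also open, going by these compounds, are how a directly attached 2,6-dichlorophenyl group would read at this place, and whether a nitrile or a methoxy group where compound 1 carries fluoro would stay within the scatter of compound 3.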